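Furan halogen shift in the acrylamide series

The source may report more compounds than this note shows. Statements on the series, on what has been measured and on what is new or still open speak of the compounds shown alone.

Compound 1 `COc1ccc(CNC(=O)/C(C#N)=C/c2ccc[nH]2)cc1` is reported in a functional assay on DU-145 cells (Homo sapiens) for inhibition, read by MTT assay, with a stated time of 72 h (on this read-out lower numbers stand for stronger inhibition of growth and higher numbers for weaker inhibition of growth), only as a limit, > 50000 nM. Compound 2 `COc1ccc(CNC(=O)/C(C#N)=C/c2ccc(Cl)o2)cc1` gives 12000 nM in this assay, the only number shown in the set. Going by the values given here, the single measured step is an at least 4.1-fold lower number from compound 1 to compound 2 (0.61 log units; beyond the scatter), and it rests on the limit of > 50000 nM in this assay, at which 1 of the 2 values shown sits, rather than on two numbers. Compound 3 `COc1ccc(CNC(=O)/C(C#N)=C/c2cc(Br)co2)cc1` carries 4-bromofuran-2-yl in place of 5-chlorofuran-2-yl on a double-bonded chain carbon bound to a double-bonded chain carbon. Among the compounds with values here, no measured step moves a halogen around the furan, so nothing bears directly on this change; the one step concerns the ring itself. The expected step is a 1.3-fold higher number from compound 2 to compound 3 (0.10 log units; within the scatter), none beyond the scatter. For compound 3 the estimate is 15000 nM, within 5000 nM to 45000 nM.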

Compound 3, concentration for 50% growth inhibition: 61000 nM
Estimate against measurement, compound 3: 4.1-fold (0.61 log units) below, and the stated range ends below it.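

With the furan kept, the halogen pattern on it still matters at this position on the double-bonded chain carbon: in this assay the change gives a 5.1-fold higher number from compound 2 to compound 3 (0.71 log units; beyond the scatter). The earlier step showed only a swap of the ring itself, whereas this one shows that the furan alone does not fix the level of growth inhibition. The step from compound 1 to compound 3 cannot be read: the limit of > 50000 nM in this assay, at which 1 of the 3 values shown sits.

On these data alone, the halogen and its place change together here, so which of them carries the step stays open. A 5-bromofuran-2-yl or 4-chlorofuran-2-yl group on the shared core would separate the two.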